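The source may hold more compounds than are shown below. What is called first, only, known or untested is meant among the compounds shown, and "the series" means these compounds.

Working notes on the series. Three compounds of this set share a core in which a sulfonamide bears an ethylene- or propylene-linked benzylamine, and all three have been run in a functional assay on PANC-1 cells (Homo sapiens) for inhibition, read by MTT assay, with a stated time of 72 h; on this read-out lower numbers stand for stronger inhibition of growth and higher numbers for weaker inhibition of growth. Compound 1 `O=S(=O)(NCCNCc1ccc(-c2ccccc2)cc1)c1cc(C(F)(F)F)cc(C(F)(F)F)c1` gives 4200 nM. Within the data shown here, compound 3 `CC(C)(C)c1ccc(CNCCNS(=O)(=O)c2cc(C(F)(F)F)cc(C(F)(F)F)c2)cc1` gives 13000 nM; the only single-point step measured so far, a 3.1-fold higher number from compound 1 to compound 3 (0.49 log units; beyond the scatter), is tert-butyl in place of phenyl on an aromatic carbon. Compound 2 `O=S(=O)(NCCCNCc1ccc(C(F)(F)F)cc1)c1cc(C(F)(F)F)cc(C(F)(F)F)c1` gives 3200 nM, the lowest of the three numbers, though compound 1 lies within the scatter of it and only compound 3 sits clearly beyond.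

Compound 4 `O=S(=O)(NCCCNCc1ccc(Cl)cc1)c1cc(C(F)(F)F)cc(C(F)(F)F)c1` is not yet measured in this assay. It differs from compound 2 in one place: chloro in place of trifluoromethyl on an aromatic carbon. Among the measured compounds shown here, no measured step touches this change; the one step on record, from compound 1 to compound 3, concerns the same aromatic carbon but swaps phenyl for tert-butyl, so it bears on it only loosely. The measured spread across the three compounds is modest, and nothing in the numbers points to a large move in either direction. The expectation is therefore a step of a 1.3-fold higher number from compound 2 to compound 4 (0.10 log units; within the scatter), with no confident direction beyond the scatter. Compound 4 is estimated at 4000 nM, with a range of 1500 nM to 11000 nM, pending measurement.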

Compound 4, concentration for 50% growth inhibition: 4900 nM
Compound 4: the middle estimate sits 1.2-fold (0.09 log units) below what was measured; the range from low to high includes it.
By their numbers in this assay, from the lowest: compounds 2, 1 and 4 (each within the scatter of the next); then compound 3.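

In this assay, chloro in place of trifluoromethyl gives a 1.5-fold higher number from compound 2 to compound 4 (0.19 log units; within the scatter), so on this read-out the two groups cannot be told apart on this aromatic carbon, para to a large group. Among these compounds, this is the first measured step at this place on the propylene-linked compounds, and it exchanges a group of 4 heavy atoms for one of 1 heavy atom without leaving the scatter. Among the compounds shown here, the other step at this place, a 3.1-fold higher number from compound 1 to compound 3 (0.49 log units; beyond the scatter), lies beyond the scatter, but it concerns a different pair of groups on the ethylene-linked compounds, so the two compounds of the new pair show only that this one exchange leaves the number within the scatter. Nothing at hand offers an explanation for either step.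

The compounds shown contain no pair that differs in the chain alone, so the ethylene and propylene links cannot be compared with each other, and a longer chain remains an open case. Also open, going by these compounds, is how an amine, a carboxylic acid or a methoxy group on this aromatic carbon would read against chloro and trifluoromethyl in this assay.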